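Three measured compounds and one step to predict

The source may report more compounds than this note shows. Statements on the series, on what has been measured and on what is new or still open speak of the compounds shown alone.

Measured so far in an ADME assay (liver) for metabolic stability, with Liver microsome (Homo sapiens) as the target, read by LC-MS, using microsomes and NADPH, with a stated time of 5 min, at 37 degrees C; a lower number here means slower removal, a higher number faster removal of the compound:
- compound 1 `CCn1c([C@@H](C)NS(=O)(=O)c2ccc(Cl)cc2)nc2cc(F)c(Cl)cc21`: > 100 mL.min-1.g-1 (a limit, not a number)
- compound 2 `CCn1c([C@@H](C)NS(=O)(=O)c2ccc(Cl)cc2)nc2cccc(Cl)c21`: > 100 mL.min-1.g-1 (a limit, not a number)
- compound 3 `CCn1c([C@@H](C)NS(=O)(=O)c2ccc(F)cc2)nc2ccc(C(F)(F)F)cc21`: 26 mL.min-1.g-1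

Compound 1 and compound 2 stand at the limit of > 100 mL.min-1.g-1 in this assay, at which 2 of the 3 values shown sit. That makes compound 3 the only one of the three with a true number in this assay, so it is the natural starting point for what follows.

Compound 4 `CCn1c([C@@H](C)NS(=O)(=O)c2cccc(C#N)c2)nc2ccc(C(F)(F)F)cc21` keeps the rest of compound 3 and carries 3-cyanophenyl in place of 4-fluorophenyl on a sulfonyl sulfur. Within the data shown here, no two measured compounds differ in one place only, so the data offer no direct guide to the size of this change.

With so little to go on, the expected 1.2-fold lower number from compound 3 to compound 4 (0.07 log units; within the scatter) is small, and it is not expected to go beyond the usual scatter in either direction. The range is kept wide to reflect this uncertainty. For compound 4 the estimated value is 22 mL.min-1.g-1, with an expected range from 9 mL.min-1.g-1 to 55 mL.min-1.g-1.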

Compound 4, intrinsic clearance in microsomes: > 100 mL.min-1.g-1
Compound 4: only a limit was reported (the forecaster's own chance of this, stated with the estimate: 5%); middle value at least 4.5-fold (0.65 log units) away from the limit.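

Among these compounds, this is the first comparison here in which only one place changes, and it shows that the group on the sulfonyl sulfur matters in this assay. Putting 3-cyanophenyl in place of 4-fluorophenyl, with the rest of the molecule unchanged, gives an at least 3.8-fold higher number from compound 3 to compound 4 (0.58 log units; beyond the scatter) and so moves the result beyond the usual scatter, toward faster removal. On these data alone, compound 4 gives > 100 mL.min-1.g-1 as a limit of the assay, not a number, so the true size of the step remains unknown, and it joins the other compounds at that ceiling: the limit of > 100 mL.min-1.g-1 in this assay, at which 3 of the 4 values shown sit.

The nitrile and its place on the ring changed in a single step, so their separate contributions cannot be told apart. As far as these compounds go, how a plain phenyl ring, or a phenyl ring carrying an amine, would behave on the sulfonyl sulfur also remains open.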